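Compound 1 to compound 4: methoxy to hydroxy

The compounds below may be only part of what the source reports. "The series", "measured", "known", "first", "only" and "open" are said of these compounds alone.

Measured so far in an ADME assay on HepG2 cells (Homo sapiens) for cytotoxicity, read by luminescence, with a stated time of 72 h (on this read-out higher numbers stand for an effect only at larger amounts of compound and lower numbers for an effect already at smaller amounts), with every value a limit:
Compound 1 (`CCOC(=O)c1c(-c2cccc(-c3ccccc3)c2)[nH]c2cc(OC)ccc2c1=O`) gives > 21500 nM as a limit
Compound 2 (`CCCOc1cccc(-c2[nH]c3cc(OC)ccc3c(=O)c2C(=O)OCC)c1`) gives > 21500 nM as a limit
Compound 3 (`CCOC(=O)c1c(-c2cccc(OC(C)C)c2)[nH]c2cc(OC)ccc2c1=O`) gives > 21500 nM as a limit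

Compound 1 stands at the limit of > 21500 nM in this assay, at which 3 of the 3 values shown sit, and so has no exact place on the scale. Compound 4 (`CCOC(=O)c1c(-c2cccc(-c3ccccc3)c2)[nH]c2cc(O)ccc2c1=O`) differs from compound 1 at one place (hydrogen in place of methyl on an oxygen on an aromatic ring) : methoxy to hydroxy, with hydrogen in place of methyl on an oxygen on an aromatic ring. The nearest evidence is a step that the two limits leave unreadable from compound 1 to compound 2 together with a step that the two limits leave unreadable from compound 1 to compound 3 and a step that the two limits leave unreadable from compound 2 to compound 3 and none of these touches the methoxy group. No readable size can be carried over from them, so no step beyond the scatter is expected in this assay in either direction. The step expected is a step that the limit leaves unreadable from compound 1 to compound 4 and it remains an estimate only. Compound 4 is expected near 25000 nM with an estimated range from 9000 nM to 60000 nM. For compound 4 too, a limit rather than an exact number may well be the outcome.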

Compound 4, half-maximal effective concentration: > 21500 nM
Compound 4 was reported as a limit; the forecaster's own chance of this, stated with the estimate: 70%; the middle value is on the limit's open side.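

Compound 1 and compound 4 are both reported only as limits, so the change from methoxy to hydroxy gives no readable step: the limit of > 21500 nM in this assay, at which 4 of the 4 values shown sit.

The compounds shown leave open where on the scale of this assay any of the four lies, and whether that change moves the read-out at all.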